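Stereochemical inversion in the bis-dioxane series: cytotoxicity notes

This account rests on a few compounds, and the source may have more. Where it says the series, first, only, none or still open, it means among the compounds named here.

Measured in an ADME assay on BHK cells (Mesocricetus auratus) for cytotoxicity, read by XTT assay; on this read-out higher numbers stand for lower toxicity in this test and lower numbers for higher toxicity in this test:
compound 1 `C(C[C@@H]1COCCO1)C[C@@H]1COCCO1`: a limit, > 1000000 nM
compound 2 `OC(C[C@@H]1COCCO1)C[C@@H]1COCCO1`: a limit, > 1000000 nM

Compound 1 stands at a limit of this assay, not at a number. Among the compounds with values here, the only other value is likewise a limit, both sitting at the limit of > 1000000 nM in this assay, at which 2 of the 2 values shown sit. Within the data shown here, the one measured step, a step that the two limits leave unreadable from compound 1 to compound 2, is therefore unreadable.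

Compound 3 `C(C[C@@H]1COCCO1)C[C@H]1COCCO1` differs from compound 1 in that (the two compounds have the same atoms and bonds and differ only in configuration as drawn: 1 of 2 stereo elements differ; a stereocentre at a saturated ring carbon is drawn R in compound 1 and S in compound 3). Among the measured compounds shown here, no measured step touches a change of configuration, and the single step available gives no size. The step of a number no higher from compound 1 to compound 3 (the limit leaves the size open) is expected to be none beyond the scatter. Compound 3 is estimated at 1000000 nM, range 300000 nM to 3000000 nM, most likely reported again only as a limit.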

Compound 3, half-maximal cytotoxic concentration: > 1000000 nM
Compound 3 gave a limit, no number; the forecaster's own chance of this, stated with the estimate: 85%; the middle value sits exactly at the limit.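

The step between compound 1 and compound 3 cannot be read in this assay, since both give only a limit: the limit of > 1000000 nM in this assay, at which 3 of the 3 values shown sit.

The compounds shown leave open whether the configuration at the saturated ring carbon affects this read-out at all, as none of them gives a number.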